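This account rests on a few compounds, and the source may have more. Where it says the series, first, only, none or still open, it means among the compounds named here.

Working notes on the oxazole series.

Among the compounds with values here, compound 2 `CCCc1nc(-c2ccccc2)c(CNCCN2CCN(c3ccc(F)cc3)CC2)o1` gives 54.1% in an assay on HEK293 cells for inhibition of Voltage-dependent T-type calcium channel subunit alpha-1G (Homo sapiens), read by fluorescence, tested at 10 uM (on this read-out lower numbers stand for less inhibition and higher numbers for more inhibition at the one concentration tested (going by the name of the read-out)), and stands lowest of the three numbers measured so far. Compound 3 `CCCc1nc(-c2ccccc2)c(CNCCCN2CCN(c3ccccc3Cl)CC2)o1` gives 64.7% in this assay, a number beyond the scatter above compound 2, and compound 1 `CCCc1nc(-c2ccccc2)c(CNCCCN2CCN(c3cccc(F)c3)CC2)o1` gives 68.9% in this assay, also beyond the scatter above compound 2. Within the data shown here, compound 1 and compound 3 differ from compound 2 in more than one place, so no single step to compound 2 can be read from them.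

Compound 4 `CCCc1nc(-c2ccccc2)c(CNCCN2CCN(c3cccc(C)c3C)CC2)o1` has not yet been measured. It differs from compound 2 only in the aryl group on the ring nitrogen: 2,3-dimethylphenyl in place of 4-fluorophenyl on an amine nitrogen in a ring. Among the measured compounds shown here, the one measured step that touches the same place is the aryl swap between compound 1 and compound 3, which gave a number 4.2 percentage points lower from compound 1 to compound 3 (within the scatter), a change within the scatter. On this single comparison the aryl group on the ring nitrogen has not moved the read-out in this assay beyond the scatter. The expectation for compound 4 is therefore a step of a number 2.9 percentage points higher from compound 2 to compound 4 (within the scatter) that stays within the scatter, with no direction claimed. Compound 4 is estimated at 57% in this assay, with a range from 42% to 72%.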

Compound 4, a percentage reported as inhibition, at one concentration (the size of the read-out at that concentration, not a potency): 66.7%
The estimate for compound 4 lay 9.7 percentage points below the measured number; low and high end bracket the measured number.
By their numbers in this assay, from the lowest: compound 2; then compounds 3, 4 and 1 (each within the scatter of the next).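

In this assay, within the data shown here, the group on the amine nitrogen in the ring can shift the read-out beyond the scatter: putting 2,3-dimethylphenyl in place of 4-fluorophenyl gives a number 12.6 percentage points higher from compound 2 to compound 4 (beyond the scatter) on the shared core, whereas the only earlier swap at this place, on the different chain shared by compound 1 and compound 3, gave a number 4.2 percentage points lower from compound 1 to compound 3 (within the scatter) and so showed no such shift. This step comes with no change in the counted features of the two groups, since each is one six-membered aromatic ring of carbon only, with 0 hydrogen-bond donors, 0 hydrogen-bond acceptors and no net charge, and the swap only exchanges 7 heavy atoms (6 carbon, 1 fluorine) for 8 heavy atoms (8 carbon). Nothing at hand accounts for the step.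

The compounds shown do not separate the loss of the fluorine from the gain of either methyl group, a question that 2-methylphenyl, 3-methylphenyl or unsubstituted phenyl at this place would address. Going by these compounds, whether the same swap gives a similar step on the chain of compound 1 and compound 3 also remains open.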